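Varying the group on the ring nitrogen of the shared core

The compounds below may be only part of what the source reports. "The series", "measured", "known", "first", "only" and "open" are said of these compounds alone.

Three compounds share one core and differ only in the group on an aromatic nitrogen. In an assay on HEK-293T cells for antagonist activity at vitamin D3 receptor (Homo sapiens), read by a luciferase reporter, with a stated time of 24 h (a lower number here means a stronger inhibitor, a higher number a weaker inhibitor), compound 1 `CCn1c(-c2ccc(OCc3c(-c4c(Cl)cccc4Cl)noc3C(C)C)cc2)nc2ccc(C(=O)O)cc21` gives 5760 nM, compound 2 `CC(C)c1onc(-c2c(Cl)cccc2Cl)c1COc1ccc(-c2nc3ccc(C(=O)O)cc3n2C2CC2)cc1` gives 3200 nM, and compound 3 `CC(C)c1onc(-c2c(Cl)cccc2Cl)c1COc1ccc(-c2nc3ccc(C(=O)O)cc3n2-c2ccc(F)cc2)cc1` gives 2410 nM, the lowest number of the three. The step of a 2.4-fold lower number from compound 1 to compound 3 (0.38 log units; beyond the scatter) was modest, while a 1.3-fold lower number from compound 2 to compound 3 (0.12 log units; within the scatter) stayed within the scatter. Compound 4 `CC(C)Cn1c(-c2ccc(OCc3c(-c4c(Cl)cccc4Cl)noc3C(C)C)cc2)nc2ccc(C(=O)O)cc21` differs from compound 3 by isobutyl in place of 4-fluorophenyl on an aromatic nitrogen. Since a chain on this nitrogen in compound 1 gave 5760 nM and a ring in compound 3 gave 2410 nM, a somewhat higher number is expected, roughly a 1.7-fold higher number from compound 3 to compound 4 (0.22 log units; within the scatter). Compound 4 is therefore estimated at 4000 nM, with a range from 2000 nM to 8000 nM.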

Compound 4, half-maximal inhibitory concentration: 1180 nM
Compound 4: middle estimate off by 3.4-fold (0.53 log units), on the high side; measured number outside the range, below it.
By their numbers in this assay, from the lowest: compound 4; then compounds 3, 2 and 1 (each within the scatter of the next, the first and the last beyond it).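

Isobutyl on this aromatic nitrogen gives a 2.0-fold lower number from compound 3 to compound 4 (0.31 log units; beyond the scatter) and a 2.7-fold lower number from compound 2 to compound 4 (0.43 log units; beyond the scatter), so the rings 4-fluorophenyl and cyclopropyl do not mark the low end of the series. The two chains instead stand at opposite ends, with a 4.9-fold lower number from compound 1 to compound 4 (0.69 log units; beyond the scatter), the widest step here, so chain against ring does not sort these compounds. No supporting data bear on why isobutyl and ethyl differ in this way. The compounds shown leave open whether a longer chain, or a chain ending in an amine, on this nitrogen would carry the number lower still.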